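The source may report more compounds than this note shows. Statements on the series, on what has been measured and on what is new or still open speak of the compounds shown alone.

Measured so far, in a functional assay on CHO cells with adenosine receptor A1 (Homo sapiens) as the target, read by cAMP accumulation and immunoassay, with a stated time of 6 min, tested at 0.01 uM; a higher number here means a weaker effect of the compound at the concentration tested, a lower number a stronger effect:
compound 1 `Nc1scc(CN2CCC(c3ccc(Cl)cc3)CC2)c1C(=O)c1ccc(Cl)cc1` gives 0%
compound 2 `Nc1scc(CN2CCN(c3c(F)cccc3F)CC2)c1C(=O)c1cccc(C(F)(F)F)c1` gives 2.1%
compound 3 `Nc1scc(CN2CCN(C3CCCCCC3)CC2)c1C(=O)c1ccc(Cl)cc1` gives 2.9%

Compound 3 carries the top number of the three, but that means little: its gap to compound 2 and its gap to compound 1 both fall within the usual scatter, so the three compounds read as one level, with no separation among them in this assay.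

Compound 4 `Nc1scc(CN2CCN(c3ccc(Cl)c(Cl)c3)CC2)c1C(=O)c1ccc(Cl)cc1` is the next member. It differs from compound 3 in one place, (3,4-dichlorophenyl in place of cycloheptyl on an amine nitrogen in a ring). Going by the values given here, no step between two measured compounds is available for this change, so the expectation rests only on the level the three measured compounds share. Since compound 3 gives 2.9% and compounds 1 and 2 give readings within the scatter of it, no step beyond the scatter is expected from compound 3 to compound 4 in this assay, in either direction.

Compound 4 is therefore estimated at 2%, with an expected range from -8% to 12%, the expected step being a number 0.9 percentage points lower from compound 3 to compound 4 (within the scatter).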

Compound 4, a percentage reported as activity, at one concentration (the size of the read-out at that concentration, not a potency): -1.2%
Compound 4: the middle estimate sits 3.2 percentage points above what was measured; the range from low to high includes it.
By their numbers in this assay, from the lowest: compounds 4, 1, 2 and 3 (each within the scatter of the next).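

In this assay, going by these compounds alone, the change to 3,4-dichlorophenyl in place of cycloheptyl on an amine nitrogen in a ring gives a number 4.1 percentage points lower from compound 3 to compound 4 (within the scatter) and is the first one-place comparison. Within the data shown here, at this position, and at the concentration tested, a six-membered aromatic ring carrying two chlorines and a seven-membered non-aromatic carbon ring are therefore not told apart, which the earlier compounds, with no pair differing in one place, could not show. Nothing measured here offers an explanation for this result.

The compounds shown leave open whether any group on this nitrogen can move the reading beyond the scatter. Going by these compounds, a carboxylic acid or a short alkyl chain in place of 3,4-dichlorophenyl would test this, and readings at other concentrations remain open too.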